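A Second Methoxy Group and Its Cost in Cytotoxicity

This account rests on a few compounds, and the source may have more. Where it says the series, first, only, none or still open, it means among the compounds named here.

Three compounds have been measured in a functional assay on HT-29 cells (Homo sapiens) for cytotoxicity, read by MTT assay, with a stated time of 72 h; on this read-out lower numbers stand for stronger inhibition and higher numbers for weaker inhibition:

Compound 1, `COc1ccc(/C=C2\S/C(=N\c3csc(-c4ccc(Cl)cc4)c3)NC2=O)cc1`, gives 3800 nM.
Compound 2, `COc1ccc(/C=C2\S/C(=N\c3csc(-c4ccc(Cl)cc4)c3)NC2=O)cc1OC`, gives 10900 nM.
Compound 3, `COc1cccc(N2C(=O)CS/C2=N\c2csc(-c3ccc(Cl)cc3)c2)c1`, gives 24600 nM.

Compound 1 and compound 2 differ by methoxy in place of hydrogen on an aromatic carbon, and this gave a 2.9-fold higher number from compound 1 to compound 2 (0.46 log units; beyond the scatter). Compound 3 carries the highest number of the three; how its core differs from that of compound 1 is not broken down here. Compound 4, `COc1ccc(N2C(=O)CS/C2=N\c2csc(-c3ccc(Cl)cc3)c2)cc1OC`, differs from compound 3 by methoxy in place of hydrogen on an aromatic carbon. This is the same kind of change as before, though here the incoming methoxy sits para to a large group, whereas in compound 2 it sits meta to a large group. A similar weakening is therefore expected, a 2.0-fold higher number from compound 3 to compound 4 (0.31 log units; beyond the scatter), because compound 3 already gives 24600 nM and the earlier change gave a 2.9-fold higher number from compound 1 to compound 2 (0.46 log units; beyond the scatter). Compound 4 is estimated at 50000 nM, expected between 20000 nM and 120000 nM.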

Compound 4, half-maximal inhibitory concentration: 14100 nM
Compound 4: the middle estimate sits 3.5-fold (0.55 log units) above what was measured; measured number below the stated range.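

On the core of compound 3, methoxy in place of hydrogen on an aromatic carbon gave a 1.7-fold lower number from compound 3 to compound 4 (0.24 log units; within the scatter) in this assay, so on this core the change has no effect that can be told from scatter. The weakening seen on the core of compound 1 therefore did not carry over to the core of compound 3, and the two steps clearly part: the same change on two cores in this assay, a 2.9-fold higher number (0.46 log units; beyond the scatter) from compound 1 to compound 2 and a 1.7-fold lower number (0.24 log units; within the scatter) from compound 3 to compound 4, 5.0-fold (0.70 log units) apart, beyond the scatter of two such steps. This rests on one pair per core, however, and it shows neither why the steps differ nor what the change would do on any further core.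

The compounds shown leave open whether a hydroxyl or an amine in the place of this methoxy would also behave differently on the two cores.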